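Extending the side chain of a weak agonist

This account rests on a few compounds, and the source may have more. Where it says the series, first, only, none or still open, it means among the compounds named here.

Compound 2 `C[C@H](C(=O)Nc1nccs1)c1ccc(Cl)cc1` was tested in a functional assay on CHO cells for agonist activity at Free fatty acid receptor 2 (Homo sapiens), read by cAMP accumulation (on this read-out lower numbers stand for stronger inhibition and higher numbers for weaker inhibition), where compound 2 gives 46000 nM. Among the two compounds measured so far, compound 2 holds the highest number; its nearest neighbour is compound 1 `CC(C)(C)[C@H](C(=O)Nc1ncc(Cc2ccc(Cl)cc2)s1)c1ccc(Cl)cc1`, which in this assay gives 25000 nM, a gap that lies within the scatter. Compound 3 `CC(C)C[C@H](C(=O)Nc1nccs1)c1ccc(Cl)cc1` has not yet been measured. It differs from compound 2 in one place: isopropyl in place of hydrogen on a saturated chain carbon, two bonds along the chain from an aromatic carbon and a carbonyl carbon. For the measured compounds named here, no step between measured compounds matches this change, so there is no measured counterpart to lean on. Compound 1 and compound 2 differ in more than one place, and their values sit within the scatter of each other, which points to a small effect of variation at this chain carbon. Compound 3 is therefore expected to give 25000 nM, within 6000 nM to 90000 nM. The step that this estimate means is a 1.8-fold lower number from compound 2 to compound 3 (0.26 log units; within the scatter), which is expected to stay close to the scatter.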

Compound 3, half-maximal inhibitory concentration: 600 nM
Compound 3: middle estimate off by 42-fold (1.62 log units), on the high side, and the stated range ends above it.
By their numbers in this assay, from the lowest: compound 3; then compounds 1 and 2 (each within the scatter of the next).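

In this assay this saturated chain carbon proves far from indifferent: with the rest of the structure unchanged, the change from methyl to isobutyl brings a 77-fold lower number from compound 2 to compound 3 (1.88 log units; beyond the scatter) and thus a large gain in this read-out. For the compounds shown here, this is the first step that isolates variation at this carbon, since the earlier pair differed in more than one place and could not show what this position alone contributes. Nothing at hand explains why the isobutyl group has this effect.

On these data alone, what remains open is whether the gain needs the branched end of the isobutyl group, or whether an unbranched butyl chain, a cyclopropylmethyl group or a longer chain would do the same. As far as these compounds go, it is equally open how a chain ending in an amine or a carboxylic acid would read at this carbon.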